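A few compounds are considered here, and "the series" means these few. Any claim that something is new, unique, unknown or untested is made for them only; others in the source may bear on it.

Of the compounds shown here, three built on one shared core have been tested in a functional assay on QGY7701 cells (Homo sapiens) for cytotoxicity, read by MTT assay, with a stated time of 48 h; on this read-out higher numbers stand for weaker inhibition and lower numbers for stronger inhibition. Compound 1 `O=c1ccoc2cc(OCc3cn(Cc4ccc(Cl)cc4)nn3)ccc12` gives 41700 nM, the highest of the three numbers. Compound 2 `O=c1ccoc2cc(OCc3cn(Cc4cccc(Br)c4)nn3)ccc12` gives 17600 nM, and compound 3 `O=c1ccoc2cc(OCc3cn(Cc4ccccc4F)nn3)ccc12` gives 36900 nM. The step of a 2.4-fold lower number from compound 1 to compound 2 (0.37 log units; beyond the scatter) is modest yet beyond the scatter, the step of a 1.1-fold lower number from compound 1 to compound 3 (0.05 log units; within the scatter) stays within it, and the step of a 2.1-fold higher number from compound 2 to compound 3 (0.32 log units; beyond the scatter) is again modest.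

Compound 4 `N#Cc1ccc(Cn2cc(COc3ccc4c(=O)ccoc4c3)nn2)cc1` is not yet measured. It differs from compound 1 in one place: cyano in place of chloro on an aromatic carbon. For the measured compounds named here, no measured step exchanges a halogen for a cyano group; each only swaps one halogen-bearing phenyl for another, and even the largest of them, a 2.4-fold lower number from compound 1 to compound 2 (0.37 log units; beyond the scatter), is modest. The data therefore give no ground to expect more than a small movement, and the direction is uncertain. Compound 4 is expected to give about 35000 nM, with a range from 15000 nM to 80000 nM. The expected step of a 1.2-fold lower number from compound 1 to compound 4 (0.08 log units; within the scatter) is thus estimated to lie within the scatter.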

Compound 4, half-maximal inhibitory concentration: > 100000 nM
Compound 4: a limit, no number; the forecaster's own chance of this, stated with the estimate: 10%; middle value at least 2.8-fold (0.45 log units) from the limit.
By their numbers in this assay, from the lowest: compound 2; then compounds 3 and 1 (each within the scatter of the next). At a limit, above all of these: compound 4.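

In this assay compound 4 gives a limit of the assay, not a number: the limit of > 100000 nM in this assay, at which 1 of the 4 values shown sits.

For the compounds shown here, this is the first change on this aromatic carbon, para to a large group, that moves the number upward from compound 1: cyano in place of chloro gives an at least 2.3-fold higher number from compound 1 to compound 4 (0.37 log units; beyond the scatter). The other two halogen-bearing compounds show the same upward direction, with an at least 2.7-fold higher number from compound 3 to compound 4 (0.43 log units; beyond the scatter) and an at least 5.6-fold higher number from compound 2 to compound 4 (0.75 log units; beyond the scatter), so leaving the halogens for a nitrile at this place weakens inhibition here, whereas the swaps among halogen-bearing phenyl groups did not raise the number beyond the scatter from compound 1.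

From the compounds shown here alone, compound 4 carries no exact number, so the full size of these steps stays open. Also open, going by these compounds, is how an amine, a carboxylic acid or a methoxy group at the same place would behave, and whether the nitrile alone or any such group would do the same.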